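A few compounds are considered here, and "the series" means these few. Any claim that something is new, unique, unknown or untested is made for them only; others in the source may bear on it.

Series notes. Three analogues sharing one core have been run in a functional assay on HEL cells (Homo sapiens); a lower number here means that less compound is tolerated, a higher number that more compound is tolerated. Compound 1 `Cc1cn([C@@H]2O[C@H](CO[Si](C)(C)C(C)(C)C)[C@@]3(OS(=O)(=O)C=C3NCC(N)=O)[C@H]2O[Si](C)(C)C(C)(C)C)c(=O)n(C)c1=O` gives 13500 nM. Compound 2 `Cc1cn([C@@H]2O[C@H](CO[Si](C)(C)C(C)(C)C)[C@@]3(OS(=O)(=O)C=C3NCC(=O)C(=O)N3CCC3)[C@H]2O[Si](C)(C)C(C)(C)C)c(=O)n(C)c1=O` gives 84400 nM, and on the two numbers shown compound 2 sits highest, its nearest neighbour being compound 1, with a 6.3-fold higher number from compound 1 to compound 2 (0.80 log units; beyond the scatter). Compound 3 `Cc1cn([C@@H]2O[C@H](CO[Si](C)(C)C(C)(C)C)[C@@]3(OS(=O)(=O)C=C3NCC(=O)OCc3ccccc3)[C@H]2O[Si](C)(C)C(C)(C)C)c(=O)n(C)c1=O` returns only a limit of the assay, > 200000 nM. Against that limit the steps read an at least 14-fold higher number from compound 1 to compound 3 (1.17 log units; beyond the scatter) and an at least 2.3-fold higher number from compound 2 to compound 3 (0.37 log units; beyond the scatter); the latter rests on (the limit of > 200000 nM in this assay, at which 1 of the 3 values shown sits).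

The next compound, compound 4 `Cc1cn([C@@H]2O[C@H](CO[Si](C)(C)C(C)(C)C)[C@@]3(OS(=O)(=O)C=C3NCCC(=O)O)[C@H]2O[Si](C)(C)C(C)(C)C)c(=O)n(C)c1=O`, is taken from compound 2 by carboxymethyl in place of ((azetidin-1-yl)carbonyl)carbonyl on a saturated chain carbon bound to an amine nitrogen. Going by the values given here, none of the measured steps repeats this change; all three concern the group on the carbonyl carbon of the same chain, and the two steps from compound 1 show that the larger groups, the (azetidin-1-yl)carbonyl and the benzyloxy, carry higher numbers, the small amino the lowest. The carboxymethyl entering in compound 4 is nearer in size to what compound 1 bears than to what leaves from compound 2, so a step back toward compound 1 is expected, a 2.1-fold lower number from compound 2 to compound 4 (0.32 log units; beyond the scatter), though a result within the scatter of compound 2 would not surprise. For compound 4 the estimate in this assay is 40000 nM, between 10000 nM and 160000 nM.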

Compound 4, half-maximal cytotoxic concentration: 34000 nM
Estimate against measurement, compound 4: 1.2-fold (0.07 log units) above, within the range that was stated.
By their numbers in this assay, from the lowest: compound 1; then compound 4; then compound 2. At a limit, above all of these: compound 3.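

Among the compounds shown, only compound 4 ends its chain in a carboxylic acid, and in this assay this end places it in the middle of the measured numbers, with a 2.5-fold lower number from compound 2 to compound 4 (0.39 log units; beyond the scatter) and a 2.5-fold higher number from compound 1 to compound 4 (0.40 log units; beyond the scatter) both beyond the scatter. The number therefore does not follow a simple split between the bulky ends and everything else: the 2-carboxyethyl chain is tolerated better than the carbamoyl end of compound 1, yet less well than the ((azetidin-1-yl)carbonyl)carbonyl end of compound 2. Compound 3, with benzyloxycarbonyl, returns only a limit, so an at least 5.8-fold lower number from compound 3 to compound 4 (0.76 log units; beyond the scatter) gives a bound and not a size for this change: the limit of > 200000 nM in this assay, at which 1 of the 4 values shown sits.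

Compound 4 differs from compound 1 in both chain length and end group, so the shift cannot yet be assigned to the carboxylic acid or to the extra chain carbon; a primary amide on the longer chain, or a carboxylic acid on the shorter one, would separate the two. A terminal amine on this chain would show whether the number depends on the kind of end group at all.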